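Shifting the chlorine on the benzamide ring

This account rests on a few compounds, and the source may have more. Where it says the series, first, only, none or still open, it means among the compounds named here.

Among the compounds with values here, compound 3 `CC(=O)Nc1cccc2c(-c3cccc(NC(=O)c4ccc(C(F)(F)F)c(Cl)c4)c3)ccnc12` gives 7600 nM in a functional assay on A375P cells (Homo sapiens) for antiproliferative activity, read by MTT assay, with a stated time of 48 h (on this read-out higher numbers stand for weaker inhibition and lower numbers for stronger inhibition), the lowest of the three numbers so far, though compound 2 `CC(=O)Nc1cccc2c(-c3cccc(NC(=O)c4cccc(C(F)(F)F)c4)c3)ccnc12`, with 8000 nM, sits within the scatter of it; only compound 1 `Nc1cccc2c(-c3cccc(NC(=O)c4cc(Cl)cc(C(F)(F)F)c4)c3)ccnc12`, at 18500 nM, lies beyond the scatter. The unmeasured compound 4 `CC(=O)Nc1cccc2c(-c3cccc(NC(=O)c4cc(Cl)cc(C(F)(F)F)c4)c3)ccnc12` differs from compound 3 by 3-chloro-5-(trifluoromethyl)phenyl in place of 3-chloro-4-(trifluoromethyl)phenyl on a carbonyl carbon. Within the data shown here, the one measured step on this ring, a 1.1-fold lower number from compound 2 to compound 3 (0.02 log units; within the scatter), changed nothing beyond the scatter. Compound 1 carries the same 3-chloro-5-(trifluoromethyl)phenyl group as compound 4 but differs from it elsewhere, so its number cannot be set directly against compound 3. For compound 4 a step of no change at the digits printed from compound 3 to compound 4 (within the scatter) is therefore expected, nothing beyond the scatter. Compound 4 is accordingly estimated at 7600 nM, within a range from 3000 nM to 19000 nM.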

Compound 4, half-maximal inhibitory concentration: 6200 nM
Compound 4: the middle estimate sits 1.2-fold (0.09 log units) above what was measured; low and high end bracket the measured number.
By their numbers in this assay, from the lowest: compounds 4, 3 and 2 (each within the scatter of the next); then compound 1.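

In this assay, changing the ring from 3-chloro-4-(trifluoromethyl)phenyl to 3-chloro-5-(trifluoromethyl)phenyl gives a 1.2-fold lower number from compound 3 to compound 4 (0.09 log units; within the scatter), and chloro in place of hydrogen gives a 1.3-fold lower number from compound 2 to compound 4 (0.11 log units; within the scatter), so neither the placing nor the presence of this chlorine registers beyond the scatter. The acetyl on the nitrogen does register, with a 3.0-fold lower number from compound 1 to compound 4 (0.47 log units; beyond the scatter), a modest step measured with this benzamide group held fixed. Nothing available explains either result. From the compounds shown here alone, whether bromo or methoxy in place of this chlorine would behave alike remains open. So does whether a longer acyl chain or a carboxylic acid on the nitrogen would match acetyl.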